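The compounds below may be only part of what the source reports. "The series", "measured", "known", "first", "only" and "open" are said of these compounds alone.

Measured compounds:
- compound 1 `O=C1c2cccc3c2c(cc2c4ccccc4oc32)C(=O)N1CN1CCNCC1` gives 11900 nM in an ADME assay on L02 cells (Homo sapiens) for cytotoxicity, read by sulforhodamine B assay; on this read-out higher numbers stand for weaker inhibition and lower numbers for stronger inhibition
- compound 2 `CCCCN1C(=O)c2cccc3c2c(cc2c4ccccc4oc32)C1=O` gives only a limit, > 100000 nM, in this assay
- compound 3 `CN(C)CCCN1C(=O)c2cccc3c2c(cc2c4ccccc4sc32)C1=O` has "not determined" (no result reported) in this assay

Compound 2 stands at the upper end of what has been measured: its result in this assay is a limit of the assay and not a number. For the measured compounds named here, the one step with numbers, an at least 8.4-fold higher number from compound 1 to compound 2 (0.92 log units; beyond the scatter), ties the loss of the basic nitrogen on the chain to this limit, and the limit itself is described by the limit of > 100000 nM in this assay, at which 1 of the 3 values shown sits.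

Compound 4 `CN(C)CCCN1C(=O)c2cccc3c2c(cc2c4ccccc4oc32)C1=O` is not yet measured. It differs from compound 2 by dimethylamino in place of methyl on a saturated chain carbon, three bonds along the chain from an amide-type nitrogen in a ring. Going by the values given here, compound 4 thus carries a basic nitrogen on its chain again, as compound 1 does, so the step of an at least 8.4-fold higher number from compound 1 to compound 2 (0.92 log units; beyond the scatter) is the only guide and points back down: a lower number in this assay is expected for compound 4, of a size comparable to that step, though the starting point being a limit leaves the size open.

The estimate for compound 4 in this assay is 30000 nM, within 10000 nM to 100000 nM, which is expected to correspond to an at least 3.3-fold lower number from compound 2 to compound 4 (0.52 log units; beyond the scatter).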

Compound 4, half-maximal inhibitory concentration: 6600 nM
The estimate for compound 4 lay 4.5-fold (0.66 log units) above the measured number; the measured number lies below the stated range.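

In this assay, butyl giving way to 3-(dimethylamino)propyl on the shared core produces an at least 15-fold lower number from compound 2 to compound 4 (1.18 log units; beyond the scatter), so the dimethylamino group at this place on the chain, three bonds along from the amide-type nitrogen in a ring, is enough to bring the series back from the top of the range without any piperazin-1-yl present. On these data alone, the value for compound 2 at one end of that step is a limit of the assay and not a number, so the true size of the step stays unknown: the limit of > 100000 nM in this assay, at which 1 of the 4 values shown sits. Piperazin-1-yl compared with 2-(dimethylamino)ethyl on the chain carbon gives a 1.8-fold lower number from compound 1 to compound 4 (0.26 log units; within the scatter), which lies within the scatter, so these two amine-bearing side chains cannot be told apart here, and the link between an amine on the chain and the lower number now rests on two different amines rather than one.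

Still open, as far as these compounds go, is whether a hydroxyl or a carboxylic acid in place of dimethylamino on the same chain would also move the number away from the limit, or whether only an amine does so. Also open, from the compounds shown here alone, is how a shorter or longer chain carrying the same dimethylamino group would read in this assay.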